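A few compounds are considered here, and "the series" means these few. Any claim that something is new, unique, unknown or untested is made for them only; others in the source may bear on it.

The study compares two measured compounds and weighs another that has not yet been tested. Compound 1, `CCCCCCCCCCCCCOC(=O)[C@H](/C=C/C(C)C)[C@H](O)[C@@H](O)[C@@H](OC)C(=O)NC1CCCCNC1=O`, gives 1200 nM in a functional assay on MDA-MB-435 cells (Homo sapiens) for antiproliferative activity; a higher number here means a weaker inhibitor, a lower number a stronger inhibitor. Compound 2, `CCCCCCCCCCCCCOC(=O)[C@H]1CCC(NC(=O)[C@H](OC)[C@H](O)[C@@H](O)[C@H](O)/C=C/C(C)C)C(=O)N(C)C1`, gives 2.4 nM in this assay. Compound 2 therefore holds the lowest number of the two, and the gap to compound 1 lies well beyond the scatter; since the two structures differ in more than one place, nothing more than the two values themselves can be read from that comparison.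

Compound 3, `CCCCCCCCCCCCCOC(=O)[C@H]1CCC(NC(=O)[C@H](OC)[C@H](O)[C@@H](O)[C@H](O)/C=C/C(C)C)C(=O)NC1`, is the next candidate. Relative to compound 2 it carries the change (hydrogen in place of methyl on an amide-type nitrogen in a ring). Within the data shown here, no measured pair in the set isolates a change of this kind, so the size of its effect is unknown. The only anchor is the strong value of compound 2 at 2.4 nM, and a single small substituent on an amide-type nitrogen in a ring is expected to move the result only moderately, most likely toward a somewhat higher number. In this assay compound 3 is therefore expected to give about 5 nM, within a range of 1 nM to 30 nM, which means an expected step of a 2.1-fold higher number from compound 2 to compound 3 (0.32 log units; beyond the scatter).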

Compound 3, half-maximal inhibitory concentration: 1 nM
The estimate for compound 3 lay 5.0-fold (0.70 log units) above the measured number; low and high end bracket the measured number.
By their numbers in this assay, from the lowest: compound 3; then compound 2; then compound 1.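

Among these compounds, replacing the methyl on the amide-type nitrogen in the ring with hydrogen gives a 2.4-fold lower number from compound 2 to compound 3 (0.38 log units; beyond the scatter) in this assay and is the first change in the set that can be read on its own. The step is modest but beyond the scatter, and it shows that the seven-membered non-aromatic ring does not need the methyl at this position: with only hydrogen on the nitrogen, compound 3 gives 1 nM and holds the lowest number of the three. Nothing measured here accounts for the direction or the size of this step.

The compounds shown carry only hydrogen or methyl on this nitrogen, which leaves open how an ethyl group, a benzyl group or a longer chain ending in an amine would read there. They also leave open whether methyl in place of the amide hydrogen in the ring of compound 1 would move its number in the same direction, so this single step cannot yet be taken as a trend.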